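Working notes: from oxan-4-yl to 3,5-dimethyl-1,2-oxazol-4-yl

A few compounds are considered here, and "the series" means these few. Any claim that something is new, unique, unknown or untested is made for them only; others in the source may bear on it.

Going by the values given here, in a physicochemical assay for lipophilicity, at pH 7.4 (on this read-out higher numbers stand for higher lipophilicity and lower numbers for lower lipophilicity), compound 2 (`CCc1ccc(N(CC(C)C)S(=O)(=O)c2ccc3c(c2)C(=O)CC(C2CCOCC2)O3)cc1`) gives 4.21 and holds the lower of the two numbers so far. Compound 1 (`CCc1ccc(N(CC(C)C)S(=O)(=O)c2ccc3c(c2)C(=O)CC(C(C)C2CCOCC2)O3)cc1`) gives 4.93 and stands higher, beyond the scatter. Among the compounds with values here, compound 3 (`CCc1ccc(N(CC(C)C)S(=O)(=O)c2ccc3c(c2)C(=O)CC(c2c(C)noc2C)O3)cc1`) carries 3,5-dimethyl-1,2-oxazol-4-yl in place of oxan-4-yl on a saturated ring carbon and has no measurement yet.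

Within the data shown here, only one measured step bears on this change: a number 0.72 log units lower from compound 1 to compound 2 (beyond the scatter) (a modest step, with oxan-4-yl in place of 1-(oxan-4-yl)ethyl on a saturated ring carbon). Among the measured compounds shown here, no measured step yet puts an aromatic ring in place of a non-aromatic one, so the direction rests on thin evidence. In that single step the larger group goes with the higher number, as compound 1 at 4.93 shows, and the entering group here is also the larger one. A modest rise is therefore expected, an estimated a number 0.34 log units higher from compound 2 to compound 3 (beyond the scatter) in this assay. The estimated value for compound 3 is 4.55 with an expected range from 4.1 to 5 on this evidence.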

Compound 3, distribution coefficient: 4.42
Beside the measured number, compound 3's estimate is 0.13 log units above it; the measured number falls inside the stated range.
By their numbers in this assay, from the lowest: compounds 2 and 3 (each within the scatter of the next); then compound 1.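

In this assay, going by these compounds alone, this is the first aromatic ring for a non-aromatic one at this position, on a saturated ring carbon next to the ring oxygen, and 3,5-dimethyl-1,2-oxazol-4-yl in place of oxan-4-yl gives a number 0.21 log units higher from compound 2 to compound 3 (within the scatter), so the read-out does not separate these two groups, and the larger entering group does not here bring a rise beyond the scatter as the one earlier step might have suggested. The same aromatic ring in place of 1-(oxan-4-yl)ethyl gives a number 0.51 log units lower from compound 1 to compound 3 (beyond the scatter), which leaves 1-(oxan-4-yl)ethyl as the only one of the three groups shown whose number stands apart from the others. No supporting measurement is available to account for these numbers.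

Still open, going by these compounds, is whether 1-(3,5-dimethyl-1,2-oxazol-4-yl)ethyl would stand apart from 3,5-dimethyl-1,2-oxazol-4-yl in the way 1-(oxan-4-yl)ethyl stands apart from oxan-4-yl. The compounds shown also leave open how this position responds to a plain phenyl ring, to an amine such as piperidin-4-yl, or to a carboxylic acid.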